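A Bromophenyl Amide Follows Three Level Analogues

The source may hold more compounds than are shown below. What is called first, only, known or untested is meant among the compounds shown, and "the series" means these compounds.

Three amides of the shared core have been measured in a physicochemical assay for lipophilicity, read by HPLC; a lower number here means a more polar compound, a higher number a more lipophilic compound. Compound 1 `Cc1ccccc1NC(=O)c1ccc2cccc(O)c2n1` gives 2.5. Compound 2 `O=C(Nc1ccccc1Cl)c1ccc2cccc(O)c2n1` gives 2.5 in this assay, and compound 3 `O=C(Nc1cccc(Cl)c1)c1ccc2cccc(O)c2n1` gives 2.5. The three steps among them are all flat: no change at the digits printed from compound 1 to compound 2 (within the scatter), no change at the digits printed from compound 1 to compound 3 (within the scatter) and no change at the digits printed from compound 2 to compound 3 (within the scatter). Compound 3 therefore stands level with compounds 1 and 2, and none of the three can be told from another beyond the scatter.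

Compound 4 `O=C(Nc1ccc(Br)cc1)c1ccc2cccc(O)c2n1` is not yet measured. It differs from compound 3 by 4-bromophenyl in place of 3-chlorophenyl on an amide-type nitrogen. Two of the measured steps bear on this change: the step from compound 2 to compound 3 rearranges the chlorophenyl group on the amide-type nitrogen, and the step from compound 1 to compound 2 puts chloro in place of methyl on an aromatic carbon; both were without change beyond the scatter. Among the measured compounds shown here, no measured step involves bromine, so nothing measured speaks directly to the exchange of chlorine for bromine. The expected step is accordingly a number 0.10 log units higher from compound 3 to compound 4 (within the scatter), a shift not beyond the scatter. Compound 4 is therefore estimated at 2.6, with a range from 2.3 to 2.9.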

Compound 4, partition coefficient: 2.5
For compound 4 the middle estimate is 0.10 log units above the measured one, within the range that was stated.
By their numbers in this assay, from the lowest: compounds 1, 2, 3 and 4 (each within the scatter of the next).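

In this assay, among the compounds shown here, 4-bromophenyl in place of 3-chlorophenyl on an amide-type nitrogen gives no change at the digits printed from compound 3 to compound 4 (within the scatter), the first step here to bring bromine to this position, and it moves the number no further than the scatter. Set against the other two amides, the same group gives no change at the digits printed from compound 2 to compound 4 (within the scatter) and no change at the digits printed from compound 1 to compound 4 (within the scatter), so all four compounds stand level and the amide-type nitrogen has so far accepted each of these substituted phenyl groups without a step beyond the scatter. Nothing available explains this flatness.

The halogen and its place on the phenyl ring change together from compound 3 to compound 4, so the two changes cannot be read apart, and a flat result for the pair may or may not mean that each alone is flat. On these data alone, it also remains open whether the number would stay level with an amine or a carboxylic acid on the phenyl ring, or with a longer chain in place of the phenyl group on the amide-type nitrogen.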